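Replacing a Fluoro Group with Acetamido on Compound 3

The source may report more compounds than this note shows. Statements on the series, on what has been measured and on what is new or still open speak of the compounds shown alone.

Compound 1 `COc1cc(/C=C2\CN(S(=O)(=O)c3ccc(F)cc3)C/C(=C\c3ccccc3F)C2=O)cc(OC)c1` gives 6890 nM 
Compound 2 `COc1cc(/C=C2\CN(S(=O)(=O)c3ccc(F)cc3)C/C(=C\c3cccc([N+](=O)[O-])c3)C2=O)cc(OC)c1OC` gives 4900 nM 
Compound 3 `COc1cc(/C=C2\CN(S(=O)(=O)c3ccc(F)cc3)C/C(=C\c3cc(OC)c(OC)c(OC)c3)C2=O)cc(OC)c1` gives 5420 nM 

These three numbers come from a functional assay on SMMC-7721 cells (Homo sapiens) for cytotoxicity, read by MTT assay, with a stated time of 24 h (on this read-out higher numbers stand for weaker inhibition and lower numbers for stronger inhibition), and lie close together. Compound 3 stands within the scatter of both others, with a 1.3-fold lower number from compound 1 to compound 3 (0.10 log units; within the scatter) and a 1.1-fold higher number from compound 2 to compound 3 (0.04 log units; within the scatter) as its two measured steps.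

Compound 4 `COc1cc(/C=C2\CN(S(=O)(=O)c3ccc(NC(C)=O)cc3)C/C(=C\c3cc(OC)c(OC)c(OC)c3)C2=O)cc(OC)c1` differs from compound 3 in one place acetamido in place of fluoro on an aromatic carbon where acetamido stands in place of fluoro on an aromatic carbon.

Both measured steps changed a phenyl group on a double-bonded chain carbon, a different part of the molecule. Within the data shown here, all three measured compounds carry the fluoro group, so no measurement yet tests this swap. Those small steps offer only weak guidance, and no direction is favoured. In this assay the expected step is a 1.1-fold lower number from compound 3 to compound 4 (0.04 log units; within the scatter) and nothing beyond the scatter is predicted, though with real uncertainty. The estimate for compound 4 is 5000 nM with an expected range from 1800 nM to 14000 nM on repeated measurement.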

Compound 4, half-maximal inhibitory concentration: 4200 nM
Compound 4: middle estimate off by 1.2-fold (0.08 log units), on the high side; the measured number falls inside the stated range.
By their numbers in this assay, from the lowest: compounds 4, 2, 3 and 1 (each within the scatter of the next).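

Among these compounds, this is the first measurement at this position: going from 4-fluorophenyl to 4-acetamidophenyl in this assay gives a 1.3-fold lower number from compound 3 to compound 4 (0.11 log units; within the scatter) and so stays within the scatter. For this one pair, then, the number does not respond measurably to exchanging a single fluorine for the four heavy atoms of acetamido, which brings a hydrogen-bond donor and a hydrogen-bond acceptor that fluoro lacks. Nothing available speaks to a cause for this result.

A single pair, carrying the same two trimethoxy-type aryl ends, cannot show whether the swap would read the same with the 2-fluorophenyl or 3-nitrophenyl groups of the other compounds. It also leaves open whether a free amine, a carboxylic acid or a longer acyl chain at this position would move the number beyond the scatter.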